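A few compounds are considered here, and "the series" means these few. Any claim that something is new, unique, unknown or untested is made for them only; others in the source may bear on it.

Series notes. Compound 3 `Nc1scc(CN2CCN(c3c(F)cc(F)cc3F)CC2)c1C(=O)c1ccc(Cl)cc1` is measured in a functional assay on CHO cells with adenosine receptor A1 (Homo sapiens) as the target, read by cAMP accumulation and immunoassay, with a stated time of 6 min, tested at 1 uM (on this read-out lower numbers stand for a stronger effect and higher numbers for a weaker effect at the one concentration tested), where compound 3 gives -56%. Among the three measured compounds this stands second highest: the nearest value is that of compound 1 `Nc1scc(CN2CCN(c3ccc(Cl)c(C(F)(F)F)c3)CC2)c1C(=O)c1ccc(Cl)cc1`, which in this assay gives -47%, and the furthest is that of compound 2 `Nc1scc(CN2CCN(c3cccc(F)c3)CC2)c1C(=O)c1ccc(Cl)cc1`, which gives -86%. The steps shown are a number 9 percentage points lower from compound 1 to compound 3 (within the scatter), a number 39 percentage points lower from compound 1 to compound 2 (beyond the scatter) and a number 30 percentage points higher from compound 2 to compound 3 (beyond the scatter).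

Compound 4 `Nc1scc(CN2CCN(c3ccc(F)c(Cl)c3)CC2)c1C(=O)c1ccc(Cl)cc1` is not yet measured. It differs from compound 3 in one place: 3-chloro-4-fluorophenyl in place of 2,4,6-trifluorophenyl on an amine nitrogen in a ring. The entering group carries two halogens on the ring, as the group of compound 1 does, and shares a single fluorine with the group of compound 2. The measured steps bearing on the change are a number 9 percentage points lower from compound 1 to compound 3 (within the scatter) and a number 30 percentage points higher from compound 2 to compound 3 (beyond the scatter); together they bracket the outcome for compound 4 between the values of compound 1 and compound 2. For compound 4 a step of about a number 6 percentage points lower from compound 3 to compound 4 (within the scatter) is expected, not beyond the scatter. Compound 4 is therefore estimated at -62% in this assay, with a range from -88% to -40%.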

Compound 4, a percentage reported as activity, at one concentration (the size of the read-out at that concentration, not a potency): -60%
The estimate for compound 4 lay 2 percentage points below the measured number; the measured number falls inside the stated range.
By their numbers in this assay, from the lowest: compound 2; then compounds 4, 3 and 1 (each within the scatter of the next, the first and the last beyond it).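

In this assay, replacing 2,4,6-trifluorophenyl on the amine nitrogen with 3-chloro-4-fluorophenyl gives a number 4 percentage points lower from compound 3 to compound 4 (within the scatter), so this position tolerates a different halogen arrangement without a readable change, while a number 13 percentage points lower from compound 1 to compound 4 (beyond the scatter) separates the new group from 4-chloro-3-(trifluoromethyl)phenyl, a separation that compound 3 did not show. Going by these compounds alone, with a number 26 percentage points higher from compound 2 to compound 4 (beyond the scatter), 3-fluorophenyl remains the only one of the four groups set apart from all the others, and the fluorine shared by compound 2 and compound 4 does not bring their numbers together. No measurement at hand offers an explanation for these differences.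

Open, on these data alone, is whether the number of compound 2 depends on fluorine at all, as an unsubstituted phenyl or a 3-methoxyphenyl group on the same nitrogen would show. Readings at one concentration also show only a stronger or weaker effect at that concentration and say nothing of how these compounds would behave at any other.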